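The source may report more compounds than this note shows. Statements on the series, on what has been measured and on what is new or still open speak of the compounds shown alone.

Of the compounds shown here, three built on the shared core have been measured in a physicochemical assay for lipophilicity, using the shake flask method, in phosphate buffer, measured as octanol-water partition, with a stated time of 85 min, at pH 7.4; a higher number here means a more lipophilic compound, a lower number a more polar compound. Compound 1 `COc1ccc(-c2cn3ccnc3c(-c3ccc4ncn(C5CCCCC5)c4c3)n2)cc1` gives 1.41, compound 2 `c1ccc2c(-c3cn4ccnc4c(-c4ccc5ncn(C6CCCCC6)c5c4)n3)cccc2c1` gives 1.44, and compound 3 `c1cn2cc(-c3ccsc3)nc(-c3ccc4ncn(C5CCCCC5)c4c3)c2n1` gives 1.81. Compound 3 thus stands highest of the three values, its gap to compound 2 being the smaller and its gap to compound 1 the larger, both beyond the scatter, while compounds 1 and 2 lie within the scatter of each other.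

Compound 4 `CCc1ccc(-c2cn3ccnc3c(-c3ccc4ncn(C5CCCCC5)c4c3)n2)cc1` has not yet been measured in this assay. It differs from compound 3 in one place: 4-ethylphenyl in place of thiophen-3-yl on an aromatic carbon. Within the data shown here, two measured steps bear on this change, each putting thiophen-3-yl onto the same aromatic carbon in place of a six-membered ring: a number 0.40 log units higher from compound 1 to compound 3 (beyond the scatter) and a number 0.37 log units higher from compound 2 to compound 3 (beyond the scatter). Compound 4 reverses that direction, so a modest fall is expected in this assay. Among the measured compounds shown here, no measured step compares 4-ethylphenyl with 4-methoxyphenyl or with naphthalen-1-yl; compounds 1 and 2 show only that those two rings give values within the scatter of each other. Compound 4 is therefore estimated at 1.5, with a range from 1.15 to 1.9, which corresponds to an expected step of a number 0.31 log units lower from compound 3 to compound 4 (beyond the scatter).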

Compound 4, partition coefficient: 1.66
For compound 4 the middle estimate is 0.16 log units below the measured one, within the range that was stated.
By their numbers in this assay, from the lowest: compounds 1, 2, 4 and 3 (each within the scatter of the next, the first and the last beyond it).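

In this assay, putting 4-ethylphenyl on this aromatic carbon in place of thiophen-3-yl gives a number 0.15 log units lower from compound 3 to compound 4 (within the scatter) and so, unlike the rings of compound 1 and compound 2, this six-membered aromatic ring is not separated from thiophen-3-yl beyond the scatter. The same new compound also stays within the scatter of the two earlier rings, with a number 0.22 log units higher from compound 2 to compound 4 (within the scatter) and, for the exchange of ethyl for methoxy, a number 0.25 log units higher from compound 1 to compound 4 (within the scatter); the earlier split between thiophen-3-yl and the six-membered rings therefore does not hold as a rule for this position, and compound 4 is the compound that goes against it. Nothing in the data shown accounts for these values.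

As far as these compounds go, it remains open whether a longer chain such as butyl, or an amine or a carboxylic acid, in the place of ethyl on the phenyl ring would lie beyond the scatter of compound 4. Also open, from the compounds shown here alone, is how another five-membered ring, such as furan-3-yl or thiophen-2-yl, on the same aromatic carbon would compare with thiophen-3-yl.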